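3-Hydroxyphenyl to 3-methoxyphenyl from compound 1

The compounds below may be only part of what the source reports. "The series", "measured", "known", "first", "only" and "open" are said of these compounds alone.

In a functional assay on UO-31 cells (Homo sapiens) for antiproliferative activity, read by sulforhodamine B assay, with a stated time of 48 h (on this read-out lower numbers stand for stronger inhibition of growth and higher numbers for weaker inhibition of growth), compound 1 `O=C(NCCCNc1cc(-c2cn(-c3ccccc3)nc2-c2cccc(O)c2)ccn1)Nc1ccc(F)cc1` gives 9700 nM, and compound 2 `O=C(NCCCNc1cc(-c2cn(-c3ccccc3)nc2-c2cccc(O)c2)ccn1)Nc1cccc(C(F)(F)F)c1` gives 10800 nM. Within the data shown here, these are the only two values, and they cannot be told apart. Compound 3 `COc1cccc(-c2nn(-c3ccccc3)cc2-c2ccnc(NCCCNC(=O)Nc3ccc(F)cc3)c2)c1` differs from compound 1 by methyl in place of hydrogen on an oxygen on an aromatic ring, hydroxy to methoxy. Among the measured compounds shown here, the one measured step, a 1.1-fold higher number from compound 1 to compound 2 (0.05 log units; within the scatter), changes a different group, on an amide-type nitrogen, and only weakly guides this change. For the measured compounds named here, no step at this oxygen has been measured, so no shift beyond the scatter is expected. The expected step is a 1.2-fold higher number from compound 1 to compound 3 (0.09 log units; within the scatter). For compound 3 the estimate is 12000 nM, with an expected range of 5000 nM to 30000 nM.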

Compound 3, concentration for total growth inhibition: > 37000 nM
Compound 3 ended at the assay's limit (the forecaster's own chance of this, stated with the estimate: 10%); middle value at least 3.0-fold (0.48 log units) from the limit.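

Methyl in place of hydrogen on an oxygen on an aromatic ring gives an at least 3.8-fold higher number from compound 1 to compound 3 (0.58 log units; beyond the scatter) in this assay. This oxygen is therefore the first place in the series where a single change moves the read-out beyond the scatter, whereas the change on the amide-type nitrogen did not. The value for compound 3 is a limit and not a number: the limit of > 37000 nM in this assay, at which 1 of the 3 values shown sits.

On these data alone, the true size of the step remains open. So does how an amine or a carboxylic acid in place of the hydroxy on 3-hydroxyphenyl would read.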